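The source may hold more compounds than are shown below. What is called first, only, known or untested is meant among the compounds shown, and "the series" means these compounds.

Measured compounds:
- Compound 1, `C/C(=N\NC(=O)c1cccc(S(=O)(=O)N2CCOCC2)c1)c1cc(O)ccc1O`: 3510 nM
- Compound 2, `C/C(=N\NC(=O)c1cccc(S(=O)(=O)N2CCOCC2)c1)c1cc(F)ccc1O`: 2210 nM
- Compound 3, `O=C(N/N=C/c1ccccn1)c1cccc(S(=O)(=O)N2CCOCC2)c1`: 44300 nM

In a functional assay on EC9706 cells (Homo sapiens) for antiproliferative activity, read by MTT assay, with a stated time of 72 h (on this read-out higher numbers stand for weaker inhibition and lower numbers for stronger inhibition), compound 3 gives the highest number of the three, and its value against those of compound 1 and compound 2 shows a gap well beyond the scatter. Compound 4, `CCOc1cccc(/C=N/NC(=O)c2cccc(S(=O)(=O)N3CCOCC3)c2)c1O`, is not yet measured. It differs from compound 3 by 3-ethoxy-2-hydroxyphenyl in place of pyridin-2-yl on a carbon with a double bond to nitrogen. Among the measured compounds shown here, the only measured step, a 1.6-fold lower number from compound 1 to compound 2 (0.20 log units; within the scatter), changes a group on a different ring and stays within the scatter, so it bears only loosely on this change. Compound 1 and compound 2, which carry a hydroxy-bearing phenyl, both give far lower numbers than compound 3, so compound 4 is expected to move toward them, a step of an 8.9-fold lower number from compound 3 to compound 4 (0.95 log units; beyond the scatter). Compound 4 is therefore estimated at 5000 nM, between 1500 nM and 20000 nM.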

Compound 4, half-maximal inhibitory concentration: 15400 nM
Beside the measured number, compound 4's estimate is 3.1-fold (0.49 log units) below it, within the range that was stated.
By their numbers in this assay, from the lowest: compounds 2 and 1 (each within the scatter of the next); then compound 4; then compound 3.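

On a carbon with a double bond to nitrogen, 3-ethoxy-2-hydroxyphenyl in place of pyridin-2-yl gives, in this assay, a 2.9-fold lower number from compound 3 to compound 4 (0.46 log units; beyond the scatter), a modest step. Among the compounds shown here, this is the first reading at this position, since the earlier step changed a group elsewhere. Nothing shown accounts for the lower number.

The compounds shown do not separate the part played by the ethoxy from that of the hydroxy. From the compounds shown here alone, what a plain phenyl or an aminophenyl would give at this position also remains open.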